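Pyrazole for tolyl on the aminopyrimidine amide series

The source may report more compounds than this note shows. Statements on the series, on what has been measured and on what is new or still open speak of the compounds shown alone.

Compound 1 `Cc1cnc(Nc2ccc(C(=O)Nc3c(C)cccc3C)cc2)nc1-c1ccc(C#N)cc1` gives 2.8 nM in an assay on NIH3T3 cells for inhibition of Sonic hedgehog protein (Mus musculus), read by a luciferase reporter, with a stated time of 48 h; a lower number here means a stronger inhibitor, a higher number a weaker inhibitor. Compound 2 `Cc1cnc(Nc2ccc(C(=O)Nc3c(C)cccc3C)cc2)nc1-c1ccc(F)cc1` gives 2.2 nM. Compound 3 `Cc1ccc(-c2nc(Nc3ccc(C(=O)Nc4c(C)cccc4C)cc3)ncc2C)cc1` is recorded only as a limit of the assay, > 500 nM; this is the limit of > 500 nM in this assay, at which 1 of the 3 values shown sits.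

Compound 3 thus stands at the weak end of the three, with no number of its own. The steps leading to it are both large: an at least 170-fold higher number from compound 1 to compound 3 (2.25 log units; beyond the scatter) and an at least 220-fold higher number from compound 2 to compound 3 (2.35 log units; beyond the scatter), while a 1.3-fold lower number from compound 1 to compound 2 (0.10 log units; within the scatter). The unmeasured compound 4 `Cc1cnc(Nc2ccc(C(=O)Nc3c(C)cccc3C)cc2)nc1-c1cnn(C)c1` differs from compound 3 by 1-methyl-1H-pyrazol-4-yl in place of 4-methylphenyl on an aromatic carbon. Among the measured compounds shown here, no measured step tests a five-membered ring in this position, so the size of the change is open. What the measured steps do show is that compound 3 with its 4-methylphenyl sits far above compounds 1 and 2, so a move away from that group is expected to lower the number, the expected step being an at least 25-fold lower number from compound 3 to compound 4 (1.39 log units; beyond the scatter). Compound 4 is therefore estimated at 20 nM, within 3 nM to 300 nM.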

Compound 4, half-maximal inhibitory concentration: 10.6 nM
Compound 4: middle estimate off by 1.9-fold (0.28 log units), on the high side; low and high end bracket the measured number.
By their numbers in this assay, from the lowest: compounds 2 and 1 (each within the scatter of the next); then compound 4. At a limit, above all of these: compound 3.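

In this assay, the position next to the ring nitrogen and ortho to a methyl group is not confined to six-membered aromatic rings: the change to 1-methyl-1H-pyrazol-4-yl gives an at least 47-fold lower number from compound 3 to compound 4 (1.67 log units; beyond the scatter). Compound 3 is held only as a limit of the assay, so that step has no fixed size: the limit of > 500 nM in this assay, at which 1 of the 4 values shown sits. Against the two better phenyl groups the same ring gives a 4.8-fold higher number from compound 2 to compound 4 (0.68 log units; beyond the scatter) and a 3.8-fold higher number from compound 1 to compound 4 (0.58 log units; beyond the scatter), so it lies short of 4-fluorophenyl and 4-cyanophenyl yet well clear of the limit of compound 3.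

The compounds shown leave open what the methyl on the pyrazole contributes; a pyrazole with hydrogen on that nitrogen, or an ethyl or longer chain there, would bear on it. They also leave open whether ring size or the ring nitrogens set the gap to compounds 1 and 2, which a thiophene would help to separate.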